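Methyl for hydroxy on the fused core

The source may hold more compounds than are shown below. What is called first, only, known or untested is meant among the compounds shown, and "the series" means these compounds.

Compound 1 `Oc1ccc2cc3c(cc2n1)C1CNCC3C1` gives 8.5 nM in an assay for binding affinity to Neuronal acetylcholine receptor; alpha4/beta2 (Rattus norvegicus) (a lower number here means a stronger inhibitor, a higher number a weaker inhibitor), the lowest of the three numbers in hand. Compound 2 `Clc1ccc(-c2cnc3cc4c(cc3n2)C2CNCC4C2)c(Cl)c1` gives 88 nM in this assay, and compound 3 `c1ccc(Cc2nc3cc4c(cc3o2)C2CNCC4C2)cc1` gives 100 nM; both gaps to compound 1 lie beyond the scatter. Among the compounds with values here, none of the three differs from another in a single place, so no measured step is available to calibrate the next change. Compound 4 `Cc1ccc2cc3c(cc2n1)C1CNCC3C1` carries the change (methyl in place of hydroxy on an aromatic carbon), methyl in place of hydroxy on an aromatic carbon. A weakening beyond the scatter is expected for compound 4, though its size is uncertain. Compound 4 is expected to give 60 nM in this assay, within 12 nM to 400 nM. The expected step is a 7.1-fold higher number from compound 1 to compound 4 (0.85 log units; beyond the scatter).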

Compound 4, inhibition constant: 0.76 nM
Beside the measured number, compound 4's estimate is 79-fold (1.90 log units) above it; measured number outside the range, below it.
By their numbers in this assay, from the lowest: compound 4; then compound 1; then compounds 2 and 3 (each within the scatter of the next).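

On the aromatic carbon next to the ring nitrogen, hydroxy is not required for a low number in this assay: methyl in its place gives an 11-fold lower number from compound 1 to compound 4 (1.05 log units; beyond the scatter). Within the data shown here, this is the first calibrated step, and it shows that the position accepts a group with no hydrogen-bond donor or acceptor. No measurement in hand bears on why the step runs in this direction. On these data alone, whether the step reflects the loss of hydroxy or the gain of methyl remains open. Methoxy, ethyl or an amine at this position would help separate the two readings.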